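This account rests on a few compounds, and the source may have more. Where it says the series, first, only, none or still open, it means among the compounds named here.

Working notes on the series. In a functional assay for inhibition, with Homo sapiens as the target (on this read-out higher numbers stand for weaker inhibition and lower numbers for stronger inhibition), compound 1 (`C#C[C@H](CC(=O)O)NC(=O)CN1CCc2ccc(N3CCNCC3)cc2C1=O`) gives 12 nM and compound 2 (`O=C(O)C[C@H](NC(=O)CN1CCc2ccc(N3CCNCC3)cc2C1=O)C1=CC=CN(O)C1`) gives 18 nM. Compound 1 has only compound 2 for comparison, and the two values lie within the scatter of each other.

Compound 3 (`C#C[C@H](CC(=O)O)NC(=O)CN1CCc2ccc(C3CCNCC3)cc2C1=O`) differs from compound 1 in one place: piperidin-4-yl in place of piperazin-1-yl on an aromatic carbon, with piperidin-4-yl in place of piperazin-1-yl on an aromatic carbon. Among the compounds with values here, the only measured step is a 1.5-fold higher number from compound 1 to compound 2 (0.18 log units; within the scatter). It lies on a saturated chain carbon bound to an amide-type nitrogen, not on the aromatic carbon, and both of its compounds carry piperazin-1-yl. It therefore bears on the new change only indirectly, and the data hold no direct test of this exchange.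

With compound 1 at 12 nM as the sole anchor, no step beyond the scatter is expected in this assay, in either direction, and the range is kept wide. The expected step is a 1.2-fold lower number from compound 1 to compound 3 (0.08 log units; within the scatter). For compound 3 the estimated value is 10 nM, with an expected range of 4 nM to 30 nM.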

Compound 3, half-maximal inhibitory concentration: 6 nM
Compound 3: middle estimate off by 1.7-fold (0.22 log units), on the high side, and the stated range covers the measured number.
By their numbers in this assay, from the lowest: compounds 3, 1 and 2 (each within the scatter of the next, the first and the last beyond it).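

Working notes, continued. In this assay, the aromatic carbon meta to a fused ring and para to a fused ring now has its first direct reading: piperidin-4-yl in place of piperazin-1-yl gives a 2.0-fold lower number from compound 1 to compound 3 (0.30 log units; within the scatter). The entering group has 1 ring hetero atom and 1 hydrogen-bond acceptor against 2 of each in the leaving group, with 1 hydrogen-bond donor in both, so on this pair a value in the low nanomolar range does not depend on the second ring nitrogen of piperazin-1-yl. No measurement on hand speaks to why the two groups read alike.

On these data alone, both groups still carry a ring nitrogen, so it remains open how a group without one, such as cyclohexyl, or a ring with oxygen in that place, such as morpholin-4-yl, or an open-chain amine would read on this aromatic carbon. Also open, as far as these compounds go, is whether piperidin-4-yl reads the same way when the saturated chain carbon bears the six-membered ring group of compound 2.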